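Replacing the guanidine of compound 1 with a urea chain

The source may hold more compounds than are shown below. What is called first, only, known or untested is meant among the compounds shown, and "the series" means these compounds.

Compound 1 `CNC(=N)Nc1nc(-c2ccc(OC)cc2)c(-c2ccc(OC)cc2)s1` is a thiazole-type core carrying two 4-methoxyphenyl groups and a short methylguanidine group. Among the measured compounds shown here, in a functional assay (aorta) with Rattus norvegicus as the target (on this read-out higher numbers stand for an effect only at larger amounts of compound and lower numbers for an effect already at smaller amounts), compound 1 gives 1.2 uM, the lowest of the three numbers known here. Compound 2 `COc1ccc(-c2nc(/N=C(\N)NC(C)C)sc2-c2ccc(OC)cc2)cc1` gives 9.1 uM in this assay, and compound 3 `COc1ccc(-c2nc(CNC(=O)c3cccnc3)sc2-c2ccc(OC)cc2)cc1` gives 8.2 uM. Both changes away from compound 1 raised the number: a 7.6-fold higher number from compound 1 to compound 2 (0.88 log units; beyond the scatter) and a 6.8-fold higher number from compound 1 to compound 3 (0.83 log units; beyond the scatter). Between the two larger groups there was no real difference, a 1.1-fold lower number from compound 2 to compound 3 (0.05 log units; within the scatter).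

Compound 4 `COc1ccc(-c2nc(CNC(=O)NC(C)C)sc2-c2ccc(OC)cc2)cc1` differs from compound 1 as follows:
a group of 8 heavy atoms (5 carbon, 2 nitrogen, 1 oxygen; no ring) in place of a group of 5 heavy atoms (2 carbon, 3 nitrogen; no ring), on an aromatic carbon
This change, like the two measured ones, swaps the small guanidine group for a larger chain that keeps a double bond and fewer donors. Both measured swaps cost a modest amount, so a similar rise is expected here, a 6.7-fold higher number from compound 1 to compound 4 (0.82 log units; beyond the scatter). Compound 4 is therefore estimated to give about 8 uM in this assay, within a range from 3 uM to 22 uM.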

Compound 4, concentration for half-maximal effect: 5.7 uM
Beside the measured number, compound 4's estimate is 1.4-fold (0.15 log units) above it, and the stated range covers the measured number.
By their numbers in this assay, from the lowest: compound 1; then compounds 4, 3 and 2 (each within the scatter of the next).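

Putting ((isopropylcarbamoyl)amino)methyl on this aromatic carbon again raises the number in this assay, with a 4.8-fold higher number from compound 1 to compound 4 (0.68 log units; beyond the scatter), so all three larger groups shown stand apart from the small group they replace. Among the compounds shown here, the single swap on the carbonyl carbon adds something new: isopropylamino in place of pyridin-3-yl changes little, with a 1.4-fold lower number from compound 3 to compound 4 (0.16 log units; within the scatter), and the step to the third larger group is also small, with a 1.6-fold lower number from compound 2 to compound 4 (0.20 log units; within the scatter). No separate measurement here helps explain these numbers.

Still open, on these data alone, is whether a plain aminomethyl group or a carboxylic acid on this carbon would come closer to the number of compound 1. As far as these compounds go, it is also open whether methylamino on the carbonyl carbon, or a longer chain there, would separate from the isopropylamino of compound 4.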